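Ethoxycarbonyl on the methyl of compound 2

This account rests on a few compounds, and the source may have more. Where it says the series, first, only, none or still open, it means among the compounds named here.

Compound 1 `CC(=O)c1sc(NNS(=O)(=O)c2ccc(C)cc2)nc1C`: 8770 nM
Compound 2 `CC(=O)N(c1nc(C)cs1)N(C(C)=O)S(=O)(=O)c1ccc(C)cc1`: 7360 nM

In a functional assay on HepG2 cells (Homo sapiens) for inhibition, read by XTT assay, with a stated time of 72 h (a lower number here means a stronger inhibitor, a higher number a weaker inhibitor), compound 2 gives 7360 nM, the lower of the two numbers, while compound 1 gives 8770 nM, and the two values lie within the scatter of each other. Compound 3 `CCOC(=O)Cc1csc(N(C(C)=O)N(C(C)=O)S(=O)(=O)c2ccc(C)cc2)n1` carries ethoxycarbonyl in place of hydrogen on a saturated chain carbon bound to an aromatic carbon. Among the compounds with values here, no measured pair shows the effect of this change, so the step from compound 2 to compound 3 in this assay is expected to be small, in either direction, and most likely not beyond the scatter, which is what a 1.1-fold lower number from compound 2 to compound 3 (0.02 log units; within the scatter) expresses. For compound 3 the estimated value in this assay is 7000 nM, with a range from 2500 nM to 20000 nM.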

Compound 3, half-maximal inhibitory concentration: 11000 nM
Compound 3: middle estimate off by 1.6-fold (0.20 log units), on the low side; measured number inside the range.
By their numbers in this assay, from the lowest: compounds 2, 1 and 3 (each within the scatter of the next).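

In this assay, within the data shown here, the change from methyl to (ethoxycarbonyl)methyl gives a 1.5-fold higher number from compound 2 to compound 3 (0.17 log units; within the scatter) and so no step beyond the scatter on this saturated chain carbon bound to an aromatic carbon, a reading that the earlier compounds, with no step between them, could not give. Nothing measured here accounts for the size of this step.

From the compounds shown here alone, whether a carboxylic acid, an amine or a longer chain in place of the ethoxycarbonyl would stay within the scatter of compound 2 remains open. So does whether any group at this position can move the number beyond the scatter.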